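Swapping a Nitro for Dimethylamino on the Aryl Imine

The source may hold more compounds than are shown below. What is called first, only, known or untested is meant among the compounds shown, and "the series" means these compounds.

Three measured compounds share one core and differ only in the aryl group on the carbon with a double bond to nitrogen. Compound 1 `COc1ccc(C2C(C#N)=C(/N=C/c3ccc(Cl)cc3)Oc3nc(Nc4ccc(S(N)(=O)=O)cc4)sc32)cc1` gives 9550 nM in a functional assay on MCF7 cells (Homo sapiens) for cytotoxicity, read by sulforhodamine B assay, with a stated time of 48 h; on this read-out lower numbers stand for stronger inhibition and higher numbers for weaker inhibition. Compound 2 `COc1ccc(C2C(C#N)=C(/N=C/c3ccc(Cl)cc3Cl)Oc3nc(Nc4ccc(S(N)(=O)=O)cc4)sc32)cc1` gives 23500 nM in this assay, and compound 3 `COc1ccc(C2C(C#N)=C(/N=C/c3ccc([N+](=O)[O-])cc3)Oc3nc(Nc4ccc(S(N)(=O)=O)cc4)sc32)cc1` gives 9700 nM. Compound 3 therefore holds the second highest of the three numbers: its nearest neighbour is compound 1, with the step of a 1.0-fold higher number from compound 1 to compound 3 (0.01 log units; within the scatter), while the step of a 2.4-fold lower number from compound 2 to compound 3 (0.38 log units; beyond the scatter) sets it apart from compound 2.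

Compound 4 `COc1ccc(C2C(C#N)=C(/N=C/c3ccc(N(C)C)cc3)Oc3nc(Nc4ccc(S(N)(=O)=O)cc4)sc32)cc1` is not yet measured. Its change from compound 3 is dimethylamino in place of nitro on an aromatic carbon. Within the data shown here, two measured steps bear on such a change. The step of a 1.0-fold higher number from compound 1 to compound 3 (0.01 log units; within the scatter) shows that exchanging one group for another on an aromatic carbon of this ring stayed within the usual scatter, whereas the step of a 2.5-fold higher number from compound 1 to compound 2 (0.39 log units; beyond the scatter) came from adding a chloro rather than exchanging a group. The like-for-like exchange is the closer precedent, so the expected step for compound 4 is a 1.0-fold lower number from compound 3 to compound 4 (0.01 log units; within the scatter). The estimated value for compound 4 is 9500 nM, within a range of 4000 nM to 24000 nM.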

Compound 4, half-maximal inhibitory concentration: 36200 nM
Compound 4: the middle estimate sits 3.8-fold (0.58 log units) below what was measured, outside the stated range (above it).
By their numbers in this assay, from the lowest: compounds 1 and 3 (each within the scatter of the next); then compounds 2 and 4 (each within the scatter of the next).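

Exchanging one group for another on this aromatic carbon can matter after all: dimethylamino in place of nitro gives a 3.7-fold higher number from compound 3 to compound 4 (0.57 log units; beyond the scatter) and dimethylamino in place of chloro gives a 3.8-fold higher number from compound 1 to compound 4 (0.58 log units; beyond the scatter) in this assay, a shift that the nitro and chloro pair alone never showed. Changing the whole aryl group gives a 1.5-fold higher number from compound 2 to compound 4 (0.19 log units; within the scatter), so 4-(dimethylamino)phenyl and 2,4-dichlorophenyl cannot be told apart in this assay. No measurement here accounts for the higher number with dimethylamino.

Among these compounds, with only one amine on this ring, it remains open whether a plain amino group or the longer diethylamino group would match compound 4 or instead match compound 1 and compound 3. On these data alone, a hydroxyl group or a carboxylic acid on this carbon is equally open.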